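The compounds below may be only part of what the source reports. "The series", "measured", "known", "first", "only" and "open" are said of these compounds alone.

Among the measured compounds shown here, compound 3 `COC(=O)[C@@]1(C)CCC=C2[C@@H]1CC[C@@H](C)[C@]2(C)Cc1c(C)[nH]c2ccc(F)cc12` shows the lowest number of the three measured so far: in a functional assay on T47D cells (Homo sapiens) for inhibition, read by sulforhodamine B assay, with a stated time of 48 h (a higher number here means a weaker inhibitor of growth, a lower number a stronger inhibitor of growth), compound 3 gives 15000 nM. Compound 2 `COC(=O)[C@@]1(C)CCC=C2[C@@H]1CC[C@@H](C)[C@]2(C)Cc1c(C)[nH]c2ccc(Cl)cc12` sits nearest, giving 17000 nM in this assay, a gap within the scatter, while compound 1 `COC(=O)[C@@]1(C)CCC=C2[C@@H]1CC[C@@H](C)[C@]2(C)Cc1c(C)[nH]c2ccc(C)cc12` gives 31000 nM. Compound 4 `COC(=O)[C@@]1(C)CCC=C2[C@@H]1CC[C@@H](C)[C@]2(C)Cc1c(C)[nH]c2ccc(OC)cc12` differs from compound 3 by methoxy in place of fluoro on an aromatic carbon. For the measured compounds named here, two measured steps concern changes of the group at this same aromatic carbon: a 2.1-fold lower number from compound 1 to compound 3 (0.32 log units; beyond the scatter) and a 1.1-fold lower number from compound 2 to compound 3 (0.05 log units; within the scatter), so exchanging groups at that carbon has moved the number only a little. A similarly small step is expected for the methoxy group, if anything toward a somewhat higher number, a 1.3-fold higher number from compound 3 to compound 4 (0.12 log units; within the scatter). Compound 4 is therefore estimated at 20000 nM, with a range from 9000 nM to 45000 nM.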

Compound 4, concentration for 50% growth inhibition: 15000 nM
The estimate for compound 4 lay 1.3-fold (0.12 log units) above the measured number; the measured number falls inside the stated range.
By their numbers in this assay, from the lowest: compounds 3, 4, 2 and 1 (each within the scatter of the next, the first and the last beyond it).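

Methoxy adds a hydrogen-bond acceptor at this aromatic carbon, yet the number holds, with no change at the digits printed from compound 3 to compound 4 (within the scatter) and with a 1.1-fold lower number from compound 2 to compound 4 (0.05 log units; within the scatter) as well. Only the exchange for methyl gives a step beyond the scatter, with a 2.1-fold lower number from compound 1 to compound 4 (0.32 log units; beyond the scatter) and it remains modest. Nothing measured here explains why this position tolerates these exchanges so evenly.

On these data alone, whether an amine, a carboxylic acid or a longer chain at this carbon would move the number further remains open.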